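A few compounds are considered here, and "the series" means these few. Any claim that something is new, unique, unknown or untested is made for them only; others in the source may bear on it.

Compound 1 `O=C1NC(=O)N(Cc2ccccc2)/C1=C/c1ccccc1` — 2.9%
Compound 2 `O=C1NC(=O)N(Cc2ccccc2)/C1=C/c1ccc(O)cc1` — 41%

In a functional assay on A549 cells (Homo sapiens) for antiproliferative activity, read by trypan blue exclusion, with a stated time of 72 h, tested at 20 uM (a higher number here means more inhibition at the concentration tested (going by the name of the read-out), a lower number less inhibition), compound 1 gives 2.9%, the lower of the two numbers; its nearest neighbour is compound 2, which gives 41%, and the step of a number 38.1 percentage points higher from compound 1 to compound 2 (beyond the scatter) lies beyond the scatter. Compound 3, `CCCCCCN1C(=O)NC(=O)/C1=C\c1ccccc1`, has not yet been measured. It differs from compound 1 by pentyl in place of phenyl on a saturated chain carbon bound to an amide-type nitrogen in a ring.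

Among the compounds with values here, the one measured step, hydroxy in place of hydrogen on an aromatic carbon, is a different kind of change at a different place from the one that separates compound 1 from compound 3, so nothing measured bears directly on this step, and the data offer no guide to its direction. Compound 1 already stands at the bottom of the range, and in the absence of any relevant step the expected change is a number 5.1 percentage points higher from compound 1 to compound 3 (within the scatter), within the scatter. In this assay compound 3 is therefore expected to give 8%, with a range from 0% to 30%.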

Compound 3, a percentage reported as inhibition, at one concentration (the size of the read-out at that concentration, not a potency): 14%
Compound 3: middle estimate off by 6 percentage points, on the low side; measured number inside the range.
By their numbers in this assay, from the lowest: compound 1; then compound 3; then compound 2.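

Within the data shown here, the earlier pair spoke only to hydroxy on an aromatic carbon; compound 3 gives the first reading for a change on a saturated chain carbon bound to an amide-type nitrogen in a ring, and it shows that this place is not silent. In this assay, pentyl in place of phenyl there gives a number 11.1 percentage points higher from compound 1 to compound 3 (beyond the scatter), a modest step, so the phenyl of the benzyl group can be given up without the number falling, and hexyl serves at least as well as benzyl on the core of compound 1. Nothing available explains the rise, and no measurement of any property of the two groups accompanies it.

With a single chain in hand, the compounds shown cannot separate the effect of losing the aromatic ring from that of the chain's length, and a shorter chain such as propyl, a longer one such as octyl, or a hexyl chain ending in an amine or a carboxylic acid could each move the number either way. They also leave open whether hydroxy on an aromatic carbon and the hexyl chain would add up when carried by one compound.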